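A few compounds are considered here, and "the series" means these few. Any claim that something is new, unique, unknown or untested is made for them only; others in the source may bear on it.

Compound 1 `O=C(O)Cn1c(=O)c(/C=C/c2ccc(O)c(O)c2)nc2cc(Cl)cnc21` and compound 3 `COc1cc(/C=C/c2nc3cc(Cl)cnc3n(CC(=O)O)c2=O)ccc1O` share one core; compound 2 `COc1cc(O)cc(-c2nc3cccnc3n(CC(=O)O)c2=O)c1` carries a different side arm, and in a functional assay, read by spectrophotometry, with a stated time of 30 min, tested at 50 uM (on this read-out lower numbers stand for a weaker effect and higher numbers for a stronger effect at the one concentration tested), compound 2 gives "not determined" (no result reported). In this assay, among the measured compounds shown here, compound 1 gives 87.4% and compound 3 gives 81.8%, so compound 3 sits alongside compound 1, the only other number reported, the step being a number 5.6 percentage points lower from compound 1 to compound 3 (within the scatter). Compound 4 `COc1cc(/C=C/c2nc3cc(Br)cnc3n(CC(=O)O)c2=O)ccc1O` differs from compound 3 by bromo in place of chloro on an aromatic carbon. For the measured compounds named here, no measured step exchanges one halogen for another; the one measured step concerns methyl in place of hydrogen on an oxygen on an aromatic ring. Going by the values given here, the step of a number 0.2 percentage points higher from compound 3 to compound 4 (within the scatter) is therefore expected to stay within the scatter, because a number 5.6 percentage points lower from compound 1 to compound 3 (within the scatter) is the only comparison available and it did too. Compound 4 is estimated at 82%, ranging from 70% to 92%.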

Compound 4, a percentage reported as activity, at one concentration (the size of the read-out at that concentration, not a potency): 75.4%
Estimate against measurement, compound 4: 6.6 percentage points above, within the range that was stated.
By their numbers in this assay, from the lowest: compounds 4, 3 and 1 (each within the scatter of the next, the first and the last beyond it).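

In this assay the series gains its first halogen exchange, on the aromatic carbon two atoms from the ring nitrogen, with a number 6.4 percentage points lower from compound 3 to compound 4 (within the scatter) as the result. Among the compounds shown here, at the one concentration tested, this read-out therefore does not separate bromo from chloro at this position, although the earlier compounds varied only the oxygen substituent on the aromatic ring. Nothing available bears on the reason for this step.

From the compounds shown here alone, whether an amine or a nitrile on this carbon would hold the read-out remains open. Also open, going by these compounds, is whether the read-out at one concentration conceals a difference in potency between the two halogens.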